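The source may hold more compounds than are shown below. What is called first, only, known or untested is meant among the compounds shown, and "the series" means these compounds.

Working notes on the series, all values from a functional assay on MDA-MB-231 cells (Homo sapiens) for antiproliferative activity, with a stated time of 4 days; a higher number here means a weaker inhibitor, a lower number a stronger inhibitor:

- compound 1 `CCCCc1ccc2[nH]c(-c3ccc(C(F)(F)F)cc3)c(/C=N/NC(=O)c3ccc(OC)cc3)c2c1` gives 284 nM
- compound 2 `CCCCc1ccc2[nH]c(-c3ccc(OC)cc3)c(/C=N/NC(=O)c3cccc(OC)c3)c2c1` gives 55 nM
- compound 3 `COc1ccc(-c2[nH]c3ccc(C)cc3c2/C=N/NC(=O)c2ccncc2)cc1` gives 290 nM

Compound 2 has the lowest number of the three and is the strongest inhibitor so far. Compound 1 and compound 3 both lie above it, beyond the scatter, and within the scatter of each other.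

The next compound to be measured is compound 4 `CCCCc1ccc2[nH]c(-c3ccc(OC)cc3)c(/C=N/NC(=O)c3ccccn3)c2c1`, which has pyridin-2-yl in place of 3-methoxyphenyl on a carbonyl carbon. Among the compounds with values here, no pair of measured compounds differs in one place only, so the series gives no direct reading of this change. Within the data shown here, the nearest hint is compound 3 at 290 nM, the one measured compound with a hetero atom in the ring on its carbonyl carbon, though it also differs from compound 2 elsewhere. The hint is weak, as compound 1 at 284 nM carries a carbon-only ring there and still falls within the scatter of compound 3.

A loss of potency beyond the scatter is expected, with an estimated 2.9-fold higher number from compound 2 to compound 4 (0.46 log units; beyond the scatter) in this assay as the size of the step. For compound 4 the expected value is 160 nM, with an estimated range of 55 nM to 450 nM for a measurement.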

Compound 4, half-maximal inhibitory concentration: 34 nM
Compound 4: the middle estimate sits 4.7-fold (0.67 log units) above what was measured, and the stated range ends above it.
By their numbers in this assay, from the lowest: compounds 4 and 2 (each within the scatter of the next); then compounds 1 and 3 (each within the scatter of the next).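

In this assay, within the data shown here, the series gives a 1.6-fold lower number from compound 2 to compound 4 (0.21 log units; within the scatter) for pyridin-2-yl in place of 3-methoxyphenyl on a carbonyl carbon, the first step in which only this position changes. The position therefore accepts a six-membered aromatic ring with one hetero atom as well as one of carbon only, and the change from 8 to 6 heavy atoms in the group leaves the two values within the scatter of each other. The data hold no measurement that explains why these two groups read alike.

Among these compounds, compound 1 and compound 3 each differ from the others in more than one place, so no steps to them can be read, and the separate contributions of the butyl chain and of the other ring remain unknown. On these data alone, it also remains open whether this position would keep the same reading with a group of a different kind, such as a saturated piperidine ring, a ring carrying a carboxylic acid, or an open alkyl chain in place of the aromatic ring.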